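The compounds below may be only part of what the source reports. "The series", "measured", "known", "first", "only" and "open" are said of these compounds alone.

Of the compounds shown here, three built on one shared core have been tested in a functional assay on CHO-K1 cells for agonist activity at Glucose-dependent insulinotropic receptor (Homo sapiens), read by a luciferase reporter, with a stated time of 5 h; on this read-out higher numbers stand for an effect only at larger amounts of compound and lower numbers for an effect already at smaller amounts. Compound 1 `CC(C)NC(=O)CN1CCN(c2ccc(OCC3CCN(C(=O)OC(C)C)CC3)cn2)CC1` carries an (isopropylcarbamoyl)methyl group on the ring amine, and in this assay compound 1 gives > 10000 nM, which is a limit of the assay and not a number: the limit of > 10000 nM in this assay, at which 1 of the 3 values shown sits. Compound 2 `CCCCS(=O)(=O)N1CCN(c2ccc(OCC3CCN(C(=O)OC(C)C)CC3)cn2)CC1` carries a butylsulfonyl group on that nitrogen instead and gives 100 nM in this assay. Compound 3 `COCCS(=O)(=O)N1CCN(c2ccc(OCC3CCN(C(=O)OC(C)C)CC3)cn2)CC1` carries a (2-methoxyethyl)sulfonyl group and gives 300 nM in this assay. Of the two real numbers, compound 3 stands highest; the step of a 3.0-fold higher number from compound 2 to compound 3 (0.48 log units; beyond the scatter) separates it from compound 2. Both sulfonyl compounds lie far from compound 1, as an at least 100-fold lower number from compound 1 to compound 2 (2.00 log units; beyond the scatter) and an at least 33-fold lower number from compound 1 to compound 3 (1.52 log units; beyond the scatter) show.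

Compound 4 `CC(C)OC(=O)N1CCC(COc2ccc(N3CCN(S(=O)(=O)c4cccs4)CC3)nc2)CC1` keeps the sulfonyl and changes only what sits on its sulfur: thiophen-2-yl in place of 2-methoxyethyl on a sulfonyl sulfur. Among the measured compounds shown here, no measured step here exchanges a chain for an aromatic ring; the only change seen on the sulfonyl substituent is the modest 3.0-fold higher number from compound 2 to compound 3 (0.48 log units; beyond the scatter), which shows that this position tolerates variation while keeping the large gain over compound 1. A modest step towards a lower number is therefore expected. Compound 4 is estimated at 150 nM, with a range from 40 nM to 600 nM, which means an expected step of a 2.0-fold lower number from compound 3 to compound 4 (0.30 log units; within the scatter).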

Compound 4, half-maximal effective concentration: 1800 nM
The estimate for compound 4 lay 12-fold (1.08 log units) below the measured number, outside the stated range (above it).
By their numbers in this assay, from the lowest: compound 2; then compound 3; then compound 4. At a limit, above all of these: compound 1.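

Among the compounds shown, this is the first exchange of a saturated chain for an aromatic ring on the sulfonyl sulfur, and in this assay it moves the number further than the change from butyl to 2-methoxyethyl did (a 6.0-fold higher number from compound 3 to compound 4 (0.78 log units; beyond the scatter); an 18-fold higher number from compound 2 to compound 4 (1.26 log units; beyond the scatter)). So the position accepts both chains shown better than it accepts thiophen-2-yl, and the choice of group on the sulfur matters more than compounds 2 and 3 alone suggested, although a sulfonyl compound still improves on the (isopropylcarbamoyl)methyl group (an at least 5.5-fold lower number from compound 1 to compound 4 (0.74 log units; beyond the scatter)). The value of compound 1 is a limit and not a number: the limit of > 10000 nM in this assay, at which 1 of the 4 values shown sits.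

No measurement shown explains why the thiophen-2-yl group gives a higher number than either chain. Also open, on these data alone, is whether a phenyl group, a methyl group or a chain carrying an amine on the sulfonyl sulfur would give a number closer to that of compound 2 or to that of compound 4.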